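A few compounds are considered here, and "the series" means these few. Any claim that something is new, unique, unknown or untested is made for them only; others in the source may bear on it.

Measured compounds in a functional assay on HeLa cells (Homo sapiens) for antiproliferative activity, read by MTT assay, with a stated time of 96 h; a lower number here means a stronger inhibitor, a higher number a weaker inhibitor:
compound 1 `O=C1NC(=O)C2(CSC3=C2C(=O)c2ncccc2C3=O)N1` gives 150 nM
compound 2 `O=C1C2=C(C(=O)c3ncccc31)C1(CS2)NC(=O)N(c2ccc([N+](=O)[O-])cc2)C1=O` gives 100 nM
compound 3 `O=C1NN(c2ccc([N+](=O)[O-])cc2)C(=O)C2(CSC3=C2C(=O)c2ncccc2C3=O)N1` gives 610 nM

Compound 2 has the lowest number of the three in this assay. Its nearest neighbour is compound 1, and the step of a 1.5-fold lower number from compound 1 to compound 2 (0.18 log units; within the scatter) is within the scatter, so the two are not separated. For the measured compounds named here, compound 3 lies furthest from compound 2; what the values of compound 2 and compound 3 show is a gap beyond the scatter, though no single-site step links these two.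

Compound 4 `CCCCCc1ccc(N2C(=O)NC3(CSC4=C3C(=O)c3ncccc3C4=O)C2=O)cc1` is compound 2 with one change: pentyl in place of nitro on an aromatic carbon. Going by the values given here, the only measured step, from compound 1 to compound 2, concerns the substituent on the ring nitrogen and does not speak to an exchange on the aromatic carbon; the pair compound 2 and compound 3 concerns a different part of the core. Among the compounds with values here, no measured step therefore bears directly on this change, and the default expectation is a step of a 1.5-fold higher number from compound 2 to compound 4 (0.18 log units; within the scatter) that stays within the scatter. Compound 4 is accordingly estimated at 150 nM in this assay, with a range from 50 nM to 500 nM.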

Compound 4, half-maximal inhibitory concentration: 200 nM
Estimate against measurement, compound 4: 1.3-fold (0.12 log units) below; measured number inside the range.
By their numbers in this assay, from the lowest: compounds 2, 1 and 4 (each within the scatter of the next); then compound 3.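

In this assay the exchange of nitro for pentyl on the aromatic carbon para to a large group gives a 2.0-fold higher number from compound 2 to compound 4 (0.30 log units; within the scatter) and so does not separate the two compounds. For the compounds shown here, this is the first measured change at this position, and the earlier compounds speak only to the substituent on the ring nitrogen and to the core. Here the hydrogen-bond acceptors of nitro leave and a chain of carbon only enters, with no change in the number beyond the scatter, and no measurement is available that would explain this result.

On these data alone, whether an amine, a carboxylic acid or a longer chain at this aromatic carbon would also stay within the scatter of compound 2 remains open. Also open, as far as these compounds go, is whether pentyl in place of nitro would give a similar step on the core of compound 3.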